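From 4-Methylpiperidine to 4-Methylpiperazine on the Shared Core

This account rests on a few compounds, and the source may have more. Where it says the series, first, only, none or still open, it means among the compounds named here.

In a functional assay on A-375 cells (Homo sapiens) for antiproliferative activity, read by CCK-8 assay, with a stated time of 72 h (on this read-out higher numbers stand for weaker inhibition and lower numbers for stronger inhibition), compound 1 (`Cc1ccc(Nc2nc(Cl)nc3c2ncn3Cc2ccc(C(=O)Nc3ccccc3N)cc2)cc1`) gives 470 nM and compound 2 (`Nc1ccccc1NC(=O)c1ccc(Cn2cnc3c(NCc4ccccc4)nc(Cl)nc32)cc1`) gives 5830 nM while compound 3 (`CC1CCN(c2nc(Cl)nc3c2ncn3Cc2ccc(C(=O)Nc3ccccc3N)cc2)CC1`) gives 4240 nM and so stands level with compound 2 and well apart from compound 1. Compound 4 (`CN1CCN(c2nc(Cl)nc3c2ncn3Cc2ccc(C(=O)Nc3ccccc3N)cc2)CC1`) keeps the shared core and places 4-methylpiperazin-1-yl in place of 4-methylpiperidin-1-yl on the same aromatic carbon: 4-methylpiperazin-1-yl in place of 4-methylpiperidin-1-yl on an aromatic carbon is the whole change. Among the measured compounds shown here, no measured step exchanges these two rings. Replacing the amino groups at that carbon gave a 9.0-fold higher number from compound 1 to compound 3 (0.96 log units; beyond the scatter) from the 4-methylphenyl compound, but only a 1.4-fold lower number from compound 2 to compound 3 (0.14 log units; within the scatter) from the benzyl compound. With the nearest comparison inside the scatter, no step beyond the scatter is expected here, and the expected step is a 1.2-fold lower number from compound 3 to compound 4 (0.08 log units; within the scatter) in this comparison. Compound 4 is estimated at 3500 nM in this assay with an expected range from 1400 nM to 9000 nM for the measurement.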

Compound 4, half-maximal inhibitory concentration: 1600 nM
Compound 4: middle estimate off by 2.2-fold (0.34 log units), on the high side, and the stated range covers the measured number.
By their numbers in this assay, from the lowest: compound 1; then compound 4; then compounds 3 and 2 (each within the scatter of the next).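

In this assay, this aromatic carbon responds to a change within the ring itself, as 4-methylpiperazin-1-yl in place of 4-methylpiperidin-1-yl gives a 2.7-fold lower number from compound 3 to compound 4 (0.42 log units; beyond the scatter). The 4-methylpiperazin-1-yl group also separates from benzylamino, with a 3.6-fold lower number from compound 2 to compound 4 (0.56 log units; beyond the scatter), but does not reach (4-methylphenyl)amino, with a 3.4-fold higher number from compound 1 to compound 4 (0.53 log units; beyond the scatter). No evidence is available to account for these steps. The compounds shown leave open whether morpholin-4-yl or unsubstituted piperazin-1-yl at this carbon would stand with compound 4 or with compound 3. They also leave open whether the step from the 4-methylpiperidin-1-yl ring would hold with an amine replacing the chloro group.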